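Replacing the carbamate on the sugar arm with a thio analogue

The source may hold more compounds than are shown below. What is called first, only, known or untested is meant among the compounds shown, and "the series" means these compounds.

Compound 2 `CCCNC(=O)OC[C@H]1OC(n2cnc3c(NC4CCOC4)ncnc32)[C@H](O)[C@@H]1O` has the highest number of the two measured compounds: in an assay on DDT1 cells (Cricetulus griseus) for binding affinity to adenosine receptor A1 (Homo sapiens), read by radioligand binding (a lower number here means a stronger inhibitor, a higher number a weaker inhibitor), compound 2 gives 235 nM, while compound 1 `CNC(=O)OC[C@H]1OC(n2cnc3c(NC4CCOC4)nc(Cl)nc32)[C@H](O)[C@@H]1O` gives 96 nM, a gap that lies beyond the usual scatter. The unmeasured compound 3 `O[C@@H]1[C@@H](CO/C(S)=N/C2CC2)OC(n2cnc3c(NC4CCOC4)ncnc32)[C@@H]1O` differs from compound 2 in a single place: a group of 6 heavy atoms (4 carbon, 1 nitrogen, 1 sulfur; one three-membered non-aromatic ring of carbon only) in place of a group of 6 heavy atoms (4 carbon, 1 nitrogen, 1 oxygen; no ring), on an oxygen on a saturated carbon. Within the data shown here, no step between measured compounds bears on this change, and compound 1 differs from compound 2 in more than one place, so its value shows only where the pair stands. With nothing to guide the direction, the change is expected to shift the number by about the size of the scatter, in either direction. Compound 3 is therefore estimated at 220 nM, with a range from 70 nM to 700 nM. That estimate means an expected step of a 1.1-fold lower number from compound 2 to compound 3 (0.03 log units; within the scatter).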

Compound 3, inhibition constant: 157 nM
Estimate against measurement, compound 3: 1.4-fold (0.15 log units) above; the measured number falls inside the stated range.
By their numbers in this assay, from the lowest: compounds 1, 3 and 2 (each within the scatter of the next, the first and the last beyond it).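

In this assay, placing the sulfur-bearing group with its three-membered carbon ring where the propylcarbamoyl stood, on the oxygen on a saturated carbon, gives a step that stays small (a 1.5-fold lower number from compound 2 to compound 3 (0.18 log units; within the scatter)). Among these compounds, this is the first step read at this place, and it shows that the oxygen-to-sulfur exchange and the exchange of an open chain for a ring, made together, leave the number within the scatter. No measurement offered here accounts for this result.

The two exchanges remain unseparated, so the compounds shown leave open what a cyclopropyl group would do with the carbonyl oxygen kept, or a propyl chain with the sulfur present. They also leave open how a longer chain, a phenyl ring or an amine would read at this place.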